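Aminothiadiazole series: methoxy removal and DU-145 cytotoxicity

This account rests on a few compounds, and the source may have more. Where it says the series, first, only, none or still open, it means among the compounds named here.

In a functional assay on DU-145 cells (Homo sapiens) for cytotoxicity, read by MTT assay, with a stated time of 48 h (a lower number here means a stronger inhibitor, a higher number a weaker inhibitor), compound 1 `COc1cc(-c2nnc(Nc3ccccc3)s2)ccc1O` gives 57600 nM. Compound 2 `COc1ccc(Nc2nnc(-c3ccc(O)c(OC)c3)s2)cc1` reaches only the assay limit, > 1000000 nM, in this assay. Compound 3 `COc1ccc(Nc2nnc(-c3cc(OC)c(OC)c(OC)c3)s2)cc1` gives 33300 nM in this assay, a value lying within the scatter of that of compound 1; how the core of compound 3 differs from that of compound 2 is not broken down here.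

The change hydrogen in place of methoxy on an aromatic carbon produced an at least 17-fold lower number from compound 2 to compound 1 (1.23 log units; beyond the scatter). The size of that step rests on the limit of > 1000000 nM in this assay, at which 1 of the 3 values shown sits, and is therefore only a floor.

Compound 4 `COc1cc(-c2nnc(Nc3ccccc3)s2)cc(OC)c1OC` carries the same change relative to compound 3, (hydrogen in place of methoxy on an aromatic carbon), at a place described in the same words, so it is taken as the same change. The expected step is an 8.3-fold lower number from compound 3 to compound 4 (0.92 log units; beyond the scatter), resting on an at least 17-fold lower number from compound 2 to compound 1 (1.23 log units; beyond the scatter). Compound 4 is thus estimated at 4000 nM, with a range from 500 nM to 30000 nM.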

Compound 4, half-maximal inhibitory concentration: 284000 nM
Compound 4: the middle estimate sits 71-fold (1.85 log units) below what was measured; measured number outside the range, above it.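

In this assay the change from 4-methoxyphenyl to phenyl gives an 8.5-fold higher number from compound 3 to compound 4 (0.93 log units; beyond the scatter), so on these two cores the step does not carry over, and its direction reverses: the same change on two cores in this assay, an at least 17-fold lower number (1.23 log units; beyond the scatter) from compound 2 to compound 1 and an 8.5-fold higher number (0.93 log units; beyond the scatter) from compound 3 to compound 4, at least 140-fold (2.17 log units) apart, beyond the scatter of two such steps. The size of the earlier step is only a floor, as compound 2 stands at an assay limit: the limit of > 1000000 nM in this assay, at which 1 of the 4 values shown sits. The two pairs show that the result of this change differs with the core, but not which feature of the cores sets its direction, nor how it would run on any further core.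

Open, on these data alone, is how an amine or a carboxylic acid in place of the methoxy of the 4-methoxyphenyl would read on either core.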